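A New Group on the Amide Nitrogen of Compound 3

This account rests on a few compounds, and the source may have more. Where it says the series, first, only, none or still open, it means among the compounds named here.

Of the compounds shown here, three sharing one core have been measured in an ADME assay on microsomes from liver (Mus musculus, strain CD-1) for metabolic stability, read by LC-MS, tested at 2 uM; a higher number here means that the compound lasts longer, a lower number that the compound disappears faster. Compound 1 `CN1CCC(NC(=O)c2ccncc2Nc2cc(-c3ccc4ccn(C)c4c3)c3nccnc3c2)CC1` gives > 1 h, which is a limit of the assay and not a number. Compound 2 `CN1CCC(NC(=O)c2ccncc2Nc2cc(-c3ccc4ccn(C)c4c3)c3nccnc3c2)CC1=O` gives 0.717 h, and compound 3 `CN1CC(NC(=O)c2ccncc2Nc2cc(-c3ccc4ccn(C)c4c3)c3nccnc3c2)CCC1=O` gives 0.75 h, so compound 3 stands level with compound 2. Compound 4 `CC(=O)N1CC(NC(=O)c2ccncc2Nc2cc(-c3ccc4ccn(C)c4c3)c3nccnc3c2)C1` carries 1-acetylazetidin-3-yl in place of 1-methyl-6-oxopiperidin-3-yl on an amide-type nitrogen.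

Among the compounds with values here, no measured step brings in a four-membered non-aromatic ring, so the guidance is indirect. The closest measured exchange is a 1.0-fold higher number from compound 2 to compound 3 (0.02 log units; within the scatter), which replaces one six-membered group with another on the same nitrogen. The other two steps carry a limit, and they are an at least 1.3-fold lower number from compound 1 to compound 2 (0.14 log units; that floor lies within the scatter) and an at least 1.3-fold lower number from compound 1 to compound 3 (0.12 log units; that floor lies within the scatter). None of these three steps is shown to lie beyond the scatter, so no clear move in either direction is expected in this assay. The expected change is no change at the digits printed from compound 3 to compound 4 (within the scatter), which would stay within the scatter. From the compounds shown here alone, the new ring remains untested here, so the expected range is kept wide. For compound 4 the estimated half-life is 0.75 h, with an expected range from 0.4 h to 1.4 h.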

Compound 4, half-life: 0.817 h
Estimate against measurement, compound 4: 1.1-fold (0.04 log units) below; low and high end bracket the measured number.
By their numbers in this assay, from the lowest: compounds 2, 3 and 4 (each within the scatter of the next). At a limit, above all of these: compound 1.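

In this assay, exchanging the six-membered ring of 1-methyl-6-oxopiperidin-3-yl for the four-membered ring of 1-acetylazetidin-3-yl gives a 1.1-fold higher number from compound 3 to compound 4 (0.04 log units; within the scatter) and the comparison with the other six-membered ring, 1-methyl-2-oxopiperidin-4-yl, gives a 1.1-fold higher number from compound 2 to compound 4 (0.06 log units; within the scatter). The earlier compounds shown here carried only six-membered rings on this amide-type nitrogen, and these steps now show that a four-membered ring with an acetyl group can sit there with no change that rises above the scatter. From the compounds shown here alone, compound 1 remains at a limit of the assay and not at a number, so the step to the new compound reads only as an at least 1.2-fold lower number from compound 1 to compound 4 (0.08 log units; that floor lies within the scatter) and the true size of that gap stays unknown: the limit of > 1 h in this assay, at which 1 of the 4 values shown sits.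

Ring size and the acetyl group enter together in compound 4, and the compounds shown cannot tell which of the two matters, if either does. A 1-acetylpiperidin-4-yl group would put the acetyl on a six-membered ring and a 1-methylazetidin-3-yl group would put a plain amine in the four-membered ring, and how each would behave in this assay is an open question.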